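The compounds below may be only part of what the source reports. "The series", "measured", "known", "first", "only" and "open" are said of these compounds alone.

Compound 1 `O[C@H]1CCCC[C@@H]1N1CCN(CCCc2ccccc2Br)CC1` and compound 2 `O[C@H]1CCCC[C@@H]1N1CCN(CCCc2cccc(Br)c2)CC1` share a core and differ only in where a bromine sits on the aromatic ring. In an assay on membranes from liver (strain Sprague-Dawley) for displacement of a labelled ligand from Sigma intracellular receptor 2 (Rattus norvegicus), read by scintillation counting, with a stated time of 90 min, in the presence of a further agent that is not named here (on this read-out lower numbers stand for stronger inhibition and higher numbers for weaker inhibition), compound 1 gives 32.5 nM, and compound 2 gives 22.2 nM. Among the measured compounds shown here, the only measured step, a 1.5-fold lower number from compound 1 to compound 2 (0.17 log units; within the scatter), lies within the scatter, so compound 1 stands at the higher of two numbers that cannot be told apart with confidence.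

Compound 3 `O[C@H]1CCC[C@@H]1N1CCN(CCCc2ccccc2Br)CC1` changes a different part of the molecule: 2-hydroxycyclopentyl in place of 2-hydroxycyclohexyl on an amine nitrogen in a ring. For the measured compounds named here, no measured step touches this ring, so the size of the change is unknown; the one step on record, being small, offers no reason to expect a large move either way. Compound 3 is therefore expected to give 40 nM in this assay, between 15 nM and 110 nM, which amounts to an estimated step of a 1.2-fold higher number from compound 1 to compound 3 (0.09 log units; within the scatter).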

Compound 3, inhibition constant: 116 nM
For compound 3 the middle estimate is 2.9-fold (0.46 log units) below the measured one, and the stated range ends below it.
By their numbers in this assay, from the lowest: compounds 2 and 1 (each within the scatter of the next); then compound 3.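

In this assay the ring on the amine nitrogen matters: 2-hydroxycyclopentyl in place of 2-hydroxycyclohexyl gives a 3.6-fold higher number from compound 1 to compound 3 (0.55 log units; beyond the scatter) and so, unlike the bromine shift between compound 1 and compound 2, this modest step lies beyond the scatter. This position therefore responds to a small edit, with weaker inhibition for the five-membered ring in this pair, even though the hydrogen-bond donor and acceptor counts of the two groups are the same. Nothing available accounts for this difference.

On these data alone, it remains open whether the same ring change would have a similar effect with the 3-bromophenyl group of compound 2. It is also unknown how a larger 2-hydroxycycloheptyl ring or an open-chain 2-hydroxyethyl group on this nitrogen would compare.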